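The source may hold more compounds than are shown below. What is called first, only, known or untested is meant among the compounds shown, and "the series" means these compounds.

Three analogues of one shared core were compared for their effect on cell growth. Compound 1 `Cn1cc(-c2nn(Cc3ccc(C(=O)N4CCCCC4)cc3)c(=O)c3ccccc23)cn1` carries a piperidin-1-yl on the carbonyl carbon; in a functional assay on HeLa cells (Homo sapiens) for antiproliferative activity, read by MTT assay, with a stated time of 72 h (a higher number here means a weaker inhibitor, a lower number a stronger inhibitor), compound 1 gives 65500 nM. Compound 2 `CN1CCC(NC(=O)c2ccc(Cn3nc(-c4cnn(C)c4)c4ccccc4c3=O)cc2)CC1`, with a (1-methylpiperidin-4-yl)amino in that place, gives 28500 nM in this assay, and a 2.3-fold lower number from compound 1 to compound 2 (0.36 log units; beyond the scatter). Compound 3 `Cn1cc(-c2nn(Cc3ccc(C(=O)NC4CC4)cc3)c(=O)c3ccccc23)cn1`, with a cyclopropylamino on the carbonyl carbon, gives 40000 nM in this assay; on these numbers compound 3 stands second highest of the three, with a 1.6-fold lower number from compound 1 to compound 3 (0.21 log units; within the scatter) and a 1.4-fold higher number from compound 2 to compound 3 (0.15 log units; within the scatter), so its value sits among those of its neighbours.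

Compound 4 `Cn1cc(-c2nn(Cc3ccc(C(=O)NC4CC(C)(C)N([O])C(C)(C)C4)cc3)c(=O)c3ccccc23)cn1` differs from compound 3 only at the amide-type nitrogen: a group of 11 heavy atoms (9 carbon, 1 nitrogen, 1 oxygen; one six-membered non-aromatic ring with 1 hetero atom) in place of a group of 3 heavy atoms (3 carbon; one three-membered non-aromatic ring of carbon only), on an amide-type nitrogen. Within the data shown here, the step that bears most directly on this change is the one from compound 2 to compound 3, where a six-membered non-aromatic ring with one hetero atom was exchanged for a cyclopropyl, and that step stayed within the scatter. The step from compound 1 to compound 2 was modest. Compound 4 is therefore expected to sit close to compound 3, with a 1.1-fold lower number from compound 3 to compound 4 (0.06 log units; within the scatter) and no direction that clearly exceeds the scatter. The estimate for compound 4 in this assay is 35000 nM, with a range from 12000 nM to 100000 nM.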

Compound 4, half-maximal inhibitory concentration: 27700 nM
For compound 4 the middle estimate is 1.3-fold (0.10 log units) above the measured one; the measured number falls inside the stated range.
By their numbers in this assay, from the lowest: compounds 4, 2, 3 and 1 (each within the scatter of the next, the first and the last beyond it).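

At the amide-type nitrogen, the group of 11 heavy atoms with its six-membered non-aromatic ring cannot be told apart in this assay from the much smaller cyclopropyl (a 1.4-fold lower number from compound 3 to compound 4 (0.16 log units; within the scatter)) or from the 1-methylpiperidin-4-yl (a 1.0-fold lower number from compound 2 to compound 4 (0.01 log units; within the scatter)), so this position has now accepted a far larger group, one with a hydrogen-bond acceptor, without any step beyond the scatter. Against the piperidin-1-yl on the carbonyl carbon, compound 4 joins compound 2 in a modest separation beyond the scatter (a 2.4-fold lower number from compound 1 to compound 4 (0.37 log units; beyond the scatter)), a separation that compound 3 does not reach, although compound 3 stays within the scatter of both compound 2 and compound 4, so no ordering by size of group can be drawn. Nothing available accounts for these readings.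

On these data alone, it stays open whether a carboxylic acid or a straight-chain primary amine at the amide-type nitrogen would move the number beyond the scatter of compound 3. The compounds shown also leave open what the oxygen of the group in compound 4 contributes, as none carries the same ring with a hydrogen in its place.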